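This account rests on a few compounds, and the source may have more. Where it says the series, first, only, none or still open, it means among the compounds named here.

Measured so far in a functional assay on B16 cells (Mus musculus) for antiproliferative activity, with a stated time of 72 h; a higher number here means a weaker inhibitor, a lower number a stronger inhibitor:
- Compound 1 `OC[C@H]1O[C@@H](n2cnc3c(NCc4ccc(F)cc4)ncnc32)[C@H](O)[C@@H]1O`: "not determined" (no result reported)
- Compound 2 `OC[C@H]1O[C@@H](n2cnc3c(NCc4ccccc4Br)ncnc32)[C@H](O)[C@@H]1O`: > 166000 nM

Compound 1 has no reported result, so it offers no point of comparison. Compound 2 gives > 166000 nM, which is a limit of the assay and not a number. Among the compounds with values here, it therefore has no exact position on the scale, and no pair of measured compounds shows how large a change of this kind can be.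

The next molecule, compound 3 `Cc1cccc(CNc2ncnc3c2ncn3[C@@H]2O[C@H](CO)[C@@H](O)[C@H]2O)c1`, has 3-methylphenyl in place of 2-bromophenyl on a saturated chain carbon bound to a nitrogen on an aromatic ring. The swap is the only difference between the two structures.

Compound 2 sits at the limit of > 166000 nM in this assay, at which 1 of the 2 values shown sits, so any number that compound 3 yields in this assay would be expected to show a stronger inhibitor, while a second limit remains quite possible. The expected change, an at least 4.1-fold lower number from compound 2 to compound 3 (0.61 log units; beyond the scatter), is a moderate gain in strength and is only loosely estimated. For compound 3 the estimated value is 40000 nM, with an expected range from 4000 nM to 166000 nM.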

Compound 3, half-maximal inhibitory concentration: > 166000 nM
Compound 3: no number, only a limit; the forecaster's own chance of this, stated with the estimate: 45%; middle value at least 4.1-fold (0.61 log units) away from the limit.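

In this assay compound 3 gives > 166000 nM, which is a limit of the assay and not a number. Compound 2 stands at a limit too, so the step between compound 2 and compound 3 cannot be read. The compounds shown leave open whether swapping 2-bromophenyl for 3-methylphenyl changes inhibitory strength at all.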